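A few compounds are considered here, and "the series" means these few. Any claim that something is new, unique, unknown or untested is made for them only; others in the source may bear on it.

Measured compounds:
Compound 1 `CC(C#CCn1ccnc1)N1CCCC1=O` gives 2 mg/kg.
Compound 2 `CC(C#CCN(C)C)N1CCCC1=O` gives > 100 mg/kg, which is a limit of the assay and not a number.
Compound 3 `Cn1ccn(CC#CCn2ccnc2)c1=O` gives > 100 mg/kg, likewise a limit of the assay.

All three values come from a functional assay on the whole organism for antagonist activity, with Mus musculus as the target; a lower number here means that less compound is needed, a higher number that more compound is needed for the effect. Between the two numbered or limited values of the first pair, the step of an at least 50-fold higher number from compound 1 to compound 2 (1.69 log units; beyond the scatter) goes with dimethylamino in place of 1H-imidazol-1-yl on a saturated chain carbon bound to a triple-bonded carbon.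

Compound 4 `CN(C)CC#CCn1ccn(C)c1=O` is not yet measured. It differs from compound 3 by dimethylamino in place of 1H-imidazol-1-yl on a saturated chain carbon bound to a triple-bonded carbon, the same change at the same place as between compound 1 and compound 2; it occurs twice among the compounds here. How the core of compound 1 and the core of compound 3 differ is not broken down here.

Compound 3 already stands at the limit of > 100 mg/kg in this assay, at which 2 of the 3 values shown sit. Compound 4 is therefore expected to give a step that the limit leaves unreadable from compound 3 to compound 4, most probably reported again only as a limit. Beside the earlier step, the expectation rests on an at least 50-fold higher number from compound 1 to compound 2 (1.69 log units; beyond the scatter) and on compound 3 sitting at the limit of > 100 mg/kg in this assay, at which 2 of the 3 values shown sit. Compound 4 is estimated at 300 mg/kg, between 100 mg/kg and 1000 mg/kg.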

Compound 4, dose for half-maximal effect: > 100 mg/kg
Compound 4 gave a limit, no number; the forecaster's own chance of this, stated with the estimate: 90%; the middle value lies beyond the limit too.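

In this assay compound 4 gives > 100 mg/kg, a limit of the assay and not a number. Compound 3 also sits at a limit, so no new step can be read from compound 3 to compound 4: the limit of > 100 mg/kg in this assay, at which 3 of the 4 values shown sit.

The compounds shown leave open whether dimethylamino in place of 1H-imidazol-1-yl changes the value on the core of compound 3.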